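The compounds below may be only part of what the source reports. "The series", "measured", "known", "first", "only" and "open" are said of these compounds alone.

Series notes, anilino variation on the shared core.

Three compounds carry the same core and differ only in the aryl on the amino nitrogen. Compound 1, `CC(C)c1ccc(-c2nc(SCc3cn(CC(=O)NC(=O)Nc4ccccn4)nn3)nc(Nc3ccc(Cl)cc3)c2C#N)cc1`, bears a 4-chlorophenyl there; in a functional assay on B16-F10 cells (Mus musculus) for inhibition, read by MTT assay, with a stated time of 72 h (on this read-out higher numbers stand for weaker inhibition and lower numbers for stronger inhibition), compound 1 gives 860 nM. Compound 2, `CC(C)c1ccc(-c2nc(SCc3cn(CC(=O)NC(=O)Nc4ccccn4)nn3)nc(Nc3cccc(Cl)c3)c2C#N)cc1`, carries the 3-chlorophenyl instead, and in this assay compound 2 gives 1130 nM. Compound 3, `CC(C)c1ccc(-c2nc(SCc3cn(CC(=O)NC(=O)Nc4ccccn4)nn3)nc(Nc3cccc(C(F)(F)F)c3)c2C#N)cc1`, has a 3-(trifluoromethyl)phenyl; in this assay compound 3 gives 1700 nM.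

Compound 2 stands second highest of the three numbers: a 1.3-fold higher number from compound 1 to compound 2 (0.12 log units; within the scatter), and a 1.5-fold higher number from compound 2 to compound 3 (0.18 log units; within the scatter). The outer step, a 2.0-fold higher number from compound 1 to compound 3 (0.30 log units; within the scatter), is likewise within the scatter. All three changes of the aryl substituent therefore leave the number essentially where it was.

Compound 4, `CC(C)c1ccc(-c2nc(SCc3cn(CC(=O)NC(=O)Nc4ccccn4)nn3)nc(Nc3ccccc3)c2C#N)cc1`, is not yet measured. The change from compound 2 reads (hydrogen in place of chloro on an aromatic carbon), at a position meta to a large group on a six-membered aromatic ring of carbon only. Among the measured compounds shown here, no measured step removes a substituent from this ring outright; the nearest precedents are the moves of the chloro around the ring and its swap for trifluoromethyl, none of which shifted the number beyond the scatter. Compound 4 is therefore expected to sit close to compound 2, with at most a small drift toward a higher number; the estimated step is a 1.2-fold higher number from compound 2 to compound 4 (0.09 log units; within the scatter). For compound 4 the estimated value in this assay is 1400 nM, within a range from 700 nM to 2800 nM.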

Compound 4, half-maximal inhibitory concentration: 14300 nM
The estimate for compound 4 lay 10-fold (1.01 log units) below the measured number; measured number outside the range, above it.
By their numbers in this assay, from the lowest: compounds 1, 2 and 3 (each within the scatter of the next); then compound 4.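

The bare phenyl shows that this ring is not indifferent to what it carries, which the swaps among compound 1, compound 2 and compound 3 could not reveal. In this assay the loss of the chloro meta to a large group is a large change (a 13-fold higher number from compound 2 to compound 4 (1.10 log units; beyond the scatter)), the same loss from the 4-chlorophenyl is also large (a 17-fold higher number from compound 1 to compound 4 (1.22 log units; beyond the scatter)), and hydrogen in place of trifluoromethyl is a modest one (an 8.4-fold higher number from compound 3 to compound 4 (0.92 log units; beyond the scatter)). Among the compounds shown, then, each of the three substituted rings stands apart from the unsubstituted one while remaining within the scatter of the others, and nothing available here accounts for that gap.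

Going by these compounds, only chloro, trifluoromethyl and hydrogen are seen on this ring, so it remains open whether a fluoro, a methyl, a methoxy or a hydroxyl would place a compound with the substituted group or with compound 4. On these data alone, it is equally open whether the gap between phenyl and substituted phenyl would persist if the pyridyl urea chain or the isopropylphenyl group of the shared core were replaced, for instance by a simple amine or a carboxylic acid.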